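The compounds below may be only part of what the source reports. "The series", "measured", "known", "first", "only" and "open" are said of these compounds alone.

Compound 1, `C/C(=C\CC/C(C)=C/CC[C@@H]1[C@@]2(C)CCC(=O)C(C)(C)[C@H]2CC[C@@]1(C)O)CC/C=C(\C)C(=O)OCc1cn(-c2cccc(O)c2)nn1`: 28400 nM
Compound 2, `C/C(=C\CC/C(C)=C/CC[C@@H]1[C@@]2(C)CCC(=O)C(C)(C)[C@H]2CC[C@@]1(C)O)CC/C=C(\C)C(=O)OCc1cn(-c2ccccc2C(F)(F)F)nn1`: > 150000 nM

Both compounds were tested in a functional assay on DU-145 cells (Homo sapiens) for antiproliferative activity, read by MTT assay, with a stated time of 48 h; a higher number here means a weaker inhibitor, a lower number a stronger inhibitor. Compound 1 gives 28400 nM. For compound 2 the assay reports only a limit, > 150000 nM. Compound 2 therefore stands at the edge of what the assay can read, as shown by the limit of > 150000 nM in this assay, at which 1 of the 2 values shown sits. For the measured compounds named here, the single measured step, an at least 5.2-fold higher number from compound 1 to compound 2 (0.72 log units; beyond the scatter), concerns a different change, 2-(trifluoromethyl)phenyl in place of 3-hydroxyphenyl on an aromatic nitrogen, and it carried the number up to that limit.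

Compound 3, `C/C(=C\CC/C(C)=C/CC[C@@H]1[C@@]2(C)CCC(=O)C(C)(C)[C@H]2CC[C@@]1(C)O)CC/C=C(\C)C(=O)OCc1cn(-c2ccccc2Br)nn1`, differs from compound 2 by bromo in place of trifluoromethyl on an aromatic carbon. Going by the values given here, no measured step covers bromo in place of trifluoromethyl, so nothing here says how far this change moves the number. Compound 2 is known only as a limit, so the size of the step cannot be fixed; a modest move in either direction would stay hidden. Compound 3 is expected to give about 120000 nM, between 40000 nM and 300000 nM. This amounts to an estimated at least 1.2-fold lower number from compound 2 to compound 3 (0.09 log units; that floor lies within the scatter), with a real chance that the assay again reports only a limit.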

Compound 3, half-maximal inhibitory concentration: > 150000 nM
Compound 3 gave a limit, no number; the forecaster's own chance of this, stated with the estimate: 50%; middle value at least 1.2-fold (0.09 log units) from the limit.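

Compound 3 shows that the loss seen with 2-(trifluoromethyl)phenyl is not tied to that one group. With 2-bromophenyl in place of 3-hydroxyphenyl on the aromatic nitrogen, this assay again gives an at least 5.2-fold higher number from compound 1 to compound 3 (0.72 log units; beyond the scatter), so two different groups at this place on the phenyl ring now fail to reach a readable value. The step between compound 2 and compound 3 cannot be read, and bromo and trifluoromethyl cannot be ranked here, because both values are limits and not numbers: the limit of > 150000 nM in this assay, at which 2 of the 3 values shown sit.

Compound 1 differs from compound 2 and compound 3 both in the group it carries and in where that group sits on the phenyl ring, so the compounds shown do not separate these two changes, and the hydroxy group itself may or may not be what keeps a number readable. From the compounds shown here alone, it also stays open whether an amine or a carboxylic acid on the phenyl ring would give a value nearer to that of compound 1 or would end at the same limit.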